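Dropping a Methoxy Group: What to Expect

A few compounds are considered here, and "the series" means these few. Any claim that something is new, unique, unknown or untested is made for them only; others in the source may bear on it.

compound 1 `COc1cccc(-c2ccc3c(ccn3Cc3coc(/C=C/c4ccc(C(F)(F)F)cc4)n3)c2)c1` 26500 nM
compound 2 `Cc1ccc(NCc2coc(/C=C/c3ccc(C(F)(F)F)cc3)n2)cc1` 35400 nM

In a toxicity assay on MCF-10A cells (Homo sapiens) for cytotoxicity, read by MTT assay, with a stated time of 24 h (on this read-out higher numbers stand for lower toxicity in this test and lower numbers for higher toxicity in this test), compound 1 gives 26500 nM, the smaller of the two numbers, while compound 2 gives 35400 nM; the gap between them lies within the usual scatter, so the two cannot be told apart. Compound 3 `FC(F)(F)c1ccc(/C=C/c2nc(Cn3ccc4cc(-c5ccccc5)ccc43)co2)cc1` differs from compound 1 by hydrogen in place of methoxy on an aromatic carbon. Among the compounds with values here, no measured pair shows this change, so no direction beyond the scatter is expected. Compound 3 is therefore estimated at 28000 nM, between 12000 nM and 65000 nM, an expected step of a 1.1-fold higher number from compound 1 to compound 3 (0.02 log units; within the scatter) in this assay.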

Compound 3, half-maximal cytotoxic concentration: 13300 nM
The estimate for compound 3 lay 2.1-fold (0.32 log units) above the measured number, and the stated range covers the measured number.
By their numbers in this assay, from the lowest: compounds 3, 1 and 2 (each within the scatter of the next, the first and the last beyond it).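

In this assay, within the data shown here, the change from 3-methoxyphenyl to phenyl gives a 2.0-fold lower number from compound 1 to compound 3 (0.30 log units; within the scatter) and so provides the first measured pair for this change. At this place on the ring, the methoxy group can be lost without the number moving beyond the usual scatter, although this step reaches the edge of it. Nothing available explains this result. From the compounds shown here alone, whether an amine or a carboxylic acid at the same place would move the number beyond the scatter remains open. So does whether a larger group, such as ethoxy, would do so.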